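Replacing the (1,3-benzoxazol-2-yl)sulfanyl group of compound 2

The source may report more compounds than this note shows. Statements on the series, on what has been measured and on what is new or still open speak of the compounds shown alone.

Compound 1 `COc1ccc(CN(C(=O)Cn2cc(COc3ccc4ccc(=O)oc4c3)nn2)c2cc(OC)c(OC)c(OC)c2)cc1`: 1300 nM
Compound 2 `COc1ccc(CN(C(=O)Cn2cc(CSc3nc4ccccc4o3)nn2)c2cc(OC)c(OC)c(OC)c2)cc1`: 15600 nM

Going by the values given here, in a functional assay on HepG2 cells (Homo sapiens) for antiproliferative activity, read by MTT assay, with a stated time of 48 h (on this read-out lower numbers stand for stronger inhibition and higher numbers for weaker inhibition), compound 2 stands at 15600 nM, the higher of the two numbers measured so far. Compound 3 `COc1ccc(CN(C(=O)Cn2cc(Cn3ccc4ccccc43)nn2)c2cc(OC)c(OC)c(OC)c2)cc1` is the next structure, and the change is 1H-indol-1-yl in place of (1,3-benzoxazol-2-yl)sulfanyl on a saturated chain carbon bound to an aromatic carbon. Among the compounds with values here, only one measured step bears on this place: a 12-fold higher number from compound 1 to compound 2 (1.08 log units; beyond the scatter). That step is large and beyond the scatter, so the group held here can matter in this assay. Neither measured compound carries 1H-indol-1-yl, however, so the data give only a loose guide. A moderate move toward a lower number is expected, smaller than the measured step, though it may not clear the scatter. The expected change is a 2.2-fold lower number from compound 2 to compound 3 (0.35 log units; beyond the scatter). For compound 3 the estimated value is 7000 nM, with an expected range from 1800 nM to 28000 nM.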

Compound 3, half-maximal inhibitory concentration: 40100 nM
Compound 3: the middle estimate sits 5.7-fold (0.76 log units) below what was measured; measured number outside the range, above it.
By their numbers in this assay, from the lowest: compound 1; then compound 2; then compound 3.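

In this assay, the new result shows that the number at this position does not fall simply on leaving (1,3-benzoxazol-2-yl)sulfanyl: 1H-indol-1-yl brings a 2.6-fold higher number from compound 2 to compound 3 (0.41 log units; beyond the scatter), a modest step but beyond the scatter. Going by these compounds alone, the group held by compound 1 therefore stands further apart from the other two, with a 31-fold higher number from compound 1 to compound 3 (1.49 log units; beyond the scatter), a large step that exceeds the one to the benzoxazole-bearing compound 2. Nothing measured here explains these differences.

The change from compound 2 to compound 3 swaps the ring system and removes the sulfur together, so the share of each remains unresolved. Also open is how an amine or a carboxylic acid on this saturated chain carbon would compare with the three groups shown.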